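The source may report more compounds than this note shows. Statements on the series, on what has been measured and on what is new or still open speak of the compounds shown alone.

Measured so far in a functional assay on A-375 cells (Homo sapiens) for inhibition; a lower number here means a stronger inhibitor, a higher number a weaker inhibitor:

compound 1, `N#CC1CN1C(=O)Nc1ccc([N+](=O)[O-])cc1`: 3900 nM
compound 2, `N#CC1CN1C(=O)Nc1ccc(C(F)(F)F)cc1`: 11800 nM

Compound 2 carries a trifluoromethyl on the aromatic ring of the shared core. In this assay compound 2 has the higher of the two numbers, so it is the weaker inhibitor of the pair; its nearest neighbour is compound 1, and the step of a 3.0-fold higher number from compound 1 to compound 2 (0.48 log units; beyond the scatter) is beyond the scatter. Compound 3, `N#CC1CN1C(=O)Nc1ccc(S(N)(=O)=O)cc1`, has not yet been measured. It differs from compound 2 in one place: sulfamoyl in place of trifluoromethyl on an aromatic carbon.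

Among the compounds with values here, only one measured step bears on this change. The step of a 3.0-fold higher number from compound 1 to compound 2 (0.48 log units; beyond the scatter) shows that swapping the group at this position of the ring moves the number by a modest amount. Within the data shown here, no measured compound carries a sulfamoyl, so there is no direct guide for the new group. With that single modest step as the only anchor, a change of similar size in either direction, or none beyond the scatter, is plausible. The expected step is a 1.7-fold lower number from compound 2 to compound 3 (0.23 log units; within the scatter). Compound 3 is therefore estimated at about 7000 nM, with a range from 2000 nM to 25000 nM.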

Compound 3, half-maximal inhibitory concentration: 188000 nM
Compound 3: middle estimate off by 27-fold (1.43 log units), on the low side; the whole stated range lies below it.
By their numbers in this assay, from the lowest: compound 1; then compound 2; then compound 3.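

In this assay, this position proves far more sensitive than the first pair suggested: a 16-fold higher number from compound 2 to compound 3 (1.20 log units; beyond the scatter) and a 48-fold higher number from compound 1 to compound 3 (1.68 log units; beyond the scatter) are both large, while the earlier swap gave only a modest step, a 3.0-fold higher number from compound 1 to compound 2 (0.48 log units; beyond the scatter). So the choice of group here can separate compounds on the shared core by much more than the first two alone could show. Sulfamoyl and trifluoromethyl have the same count of heavy atoms, so that count alone does not distinguish them, although sulfamoyl carries a hydrogen-bond donor and acceptors and trifluoromethyl carries neither. Nothing available explains why this change raises the number so sharply.

The three compounds leave open whether the large step belongs to the sulfamoyl as a whole or to its nitrogen and the hydrogens on it, and a methylsulfonyl group in the same place would help separate those two readings. On these data alone, it also remains open whether a carboxylic acid or an amine at this position would give a similarly large step or stay closer to compound 1 and compound 2.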